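The compounds below may be only part of what the source reports. "The series", "measured", "known", "first", "only" and "open" are said of these compounds alone.

Measured so far:
compound 1 `O=c1[nH]c2ccccc2n1CCCN1CCC(C(O)(c2ccccc2)c2ccccc2)CC1`: in an assay on RPMI-8226 cells for antagonist activity at P2X purinoceptor 7 (Homo sapiens), read by calcium flux (a lower number here means a stronger inhibitor, a higher number a weaker inhibitor), compound 1 gives 7500 nM
compound 2 `Cc1ccc2ccn(CCCCN3CCN(C(c4ccccc4)c4ccccc4)CC3)c2c1`: in this assay compound 2 gives 6500 nM

Compound 2 carries the lower of the two numbers, but compound 1 sits within the scatter of it, so no order between the two can be read from these data. Compound 3 `N#Cc1ccc2c(ccn2CCCCN2CCN(C(c3ccccc3)c3ccccc3)CC2)c1` has not been measured. It differs from compound 2 by a group of 11 heavy atoms (9 carbon, 2 nitrogen; one five-membered aromatic ring with 1 hetero atom, one six-membered aromatic ring of carbon only) in place of a group of 10 heavy atoms (9 carbon, 1 nitrogen; one five-membered aromatic ring with 1 hetero atom, one six-membered aromatic ring of carbon only), on a saturated chain carbon, four bonds along the chain from an amine nitrogen in a ring. Within the data shown here, no pair of measured compounds differs in a single place, so there is no measured step that mirrors this change; what can be said rests on compound 2 alone. The change is expected to give a small step at most, in either direction, probably not clearly beyond the scatter, with a slight lean toward a lower number. Compound 3 is therefore estimated at 5000 nM in this assay, with a range of 1500 nM to 15000 nM. That estimate corresponds to an expected step of a 1.3-fold lower number from compound 2 to compound 3 (0.11 log units; within the scatter).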

Compound 3, half-maximal inhibitory concentration: 3800 nM
For compound 3 the middle estimate is 1.3-fold (0.12 log units) above the measured one; low and high end bracket the measured number.
By their numbers in this assay, from the lowest: compounds 3, 2 and 1 (each within the scatter of the next).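

In this assay the series now has its first comparison at a single place, and it reads a 1.7-fold lower number from compound 2 to compound 3 (0.23 log units; within the scatter). On the saturated chain carbon, four bonds along the chain from an amine nitrogen in a ring, 5-cyano-1H-indol-1-yl can therefore take the place of the earlier group with no step beyond the scatter, though this rests on one pair only and gives no direction. Nothing measured on these compounds bears on the reason for this reading.

Open, as far as these compounds go, is whether a carboxylic acid or an amine in place of the nitrile would give a step beyond the scatter. Also open, from the compounds shown here alone, is whether a longer chain between the two ring systems would shift the number, since compound 1 differs from the others in more than one place.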